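This account rests on a few compounds, and the source may have more. Where it says the series, first, only, none or still open, it means among the compounds named here.

Measured compounds:
compound 1 `O=C(NO)c1ccc(N(Cc2ccc(C3CCOCC3)cc2)C(=O)[C@H]2CCN2S(=O)(=O)c2c(F)c(F)c(F)c(F)c2F)cc1`, 4000 nM
compound 2 `CONC(=O)c1ccc(N(Cc2ccc(C3CCCCC3)cn2)C(=O)[C@H]2CCN2S(=O)(=O)c2c(F)c(F)c(F)c(F)c2F)c(F)c1`, "not determined" (no result reported)

In a functional assay on MDA-MB-231 cells (Homo sapiens) for antiproliferative activity, with a stated time of 72 h (a higher number here means that more compound is needed for the effect, a lower number that less compound is needed), compound 1 gives 4000 nM. Compound 2 shares the core of compound 1 but carries a methoxycarbamoyl group and a fluorine on the ring at the amide-type nitrogen, and a cyclohexyl-substituted pyridine on the chain carbon; for compound 2 no number in this assay was reported, so its standing cannot be placed against compound 1. Compound 3 `O=C([C@H]1CCN1S(=O)(=O)c1c(F)c(F)c(F)c(F)c1F)N(Cc1ccc(C2CCCCC2)cn1)c1cc2[nH]ncc2cc1F` keeps the pyridine side of compound 2 and differs from it in one place: 5-fluoro-1H-indazol-6-yl in place of 2-fluoro-4-(methoxycarbamoyl)phenyl on an amide-type nitrogen. Among the compounds with values here, no measured pair describes this change, so the size and direction of the step from compound 2 to compound 3 in this assay cannot be read from the data; only compound 1 offers a reference point, and it differs from compound 3 in more than one place. The estimate for compound 3 therefore rests loosely on the value of compound 1 and carries a wide range. Compound 3 is expected to give about 3000 nM in this assay, estimated between 400 nM and 25000 nM.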

Compound 3, half-maximal effective concentration: 2300 nM
Compound 3: the middle estimate sits 1.3-fold (0.12 log units) above what was measured; measured number inside the range.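

In this assay, within the data shown here, compound 3 gives 2300 nM while compound 2 has no reported number, so no step between compound 2 and compound 3 can be read. The compounds shown leave open what 5-fluoro-1H-indazol-6-yl does in place of 2-fluoro-4-(methoxycarbamoyl)phenyl on the amide-type nitrogen. No evidence bearing on this result is at hand.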